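Swapping ethoxycarbonyl for nitro in compound 3

The source may hold more compounds than are shown below. What is called first, only, known or untested is meant among the compounds shown, and "the series" means these compounds.

Measured in a functional assay on MDA-MB-231 cells (Homo sapiens) for antiproliferative activity, read by MTT assay, with a stated time of 72 h; a lower number here means a stronger inhibitor, a higher number a weaker inhibitor:
- compound 1 `O=C(CCc1cccc2c1B(O)OC2)Nc1ccc(I)cc1`: 33000 nM
- compound 2 `CC(C)(C)c1ccc(NC(=O)CCc2cccc3c2B(O)OC3)cc1`: 33000 nM
- compound 3 `CCOC(=O)c1ccc(NC(=O)CCc2cccc3c2B(O)OC3)cc1`: > 100000 nM (a limit, not a number)

Compound 3 gives only a limit, > 100000 nM. Compound 4 `O=C(CCc1cccc2c1B(O)OC2)Nc1ccc([N+](=O)[O-])cc1` carries nitro in place of ethoxycarbonyl on an aromatic carbon.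

For the measured compounds named here, two measured steps bear on this change: an at least 3.0-fold higher number from compound 1 to compound 3 (0.48 log units; beyond the scatter) and an at least 3.0-fold higher number from compound 2 to compound 3 (0.48 log units; beyond the scatter). Both sizes rest on (the limit of > 100000 nM in this assay, at which 1 of the 3 values shown sits). A third step, no change at the digits printed from compound 1 to compound 2 (within the scatter), shows that iodo and tert-butyl match. Nitro has not been tested, so it may match those two groups or stay with ethoxycarbonyl. A modest move to a lower number is therefore expected in this assay, similar in size to those two steps. The expected change is an at least 2.0-fold lower number from compound 3 to compound 4 (0.30 log units; that floor lies within the scatter). The estimated value for compound 4 is 50000 nM, with an expected range from 20000 nM to 100000 nM.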

Compound 4, half-maximal inhibitory concentration: 36000 nM
Estimate against measurement, compound 4: 1.4-fold (0.14 log units) above; measured number inside the range.
By their numbers in this assay, from the lowest: compounds 1, 2 and 4 (each within the scatter of the next). At a limit, above all of these: compound 3.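

In this assay, nitro on this aromatic carbon matches iodo and tert-butyl, with a 1.1-fold higher number from compound 1 to compound 4 (0.04 log units; within the scatter) and a 1.1-fold higher number from compound 2 to compound 4 (0.04 log units; within the scatter). Three quite different groups now give matching results, which leaves ethoxycarbonyl as the only one of the four that stands apart, with an at least 2.7-fold lower number from compound 3 to compound 4 (0.44 log units; beyond the scatter). That step is only a minimum, as compound 3 gives a limit and not a number: the limit of > 100000 nM in this assay, at which 1 of the 4 values shown sits.

What sets ethoxycarbonyl apart remains unclear. Going by these compounds, it is also open whether an amine or a carboxylic acid in this place would match nitro or stay with ethoxycarbonyl.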